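Removing the Carbamate From Compound 3: An Expected Response

The compounds below may be only part of what the source reports. "The series", "measured", "known", "first", "only" and "open" are said of these compounds alone.

Measured in a functional assay on isolated protein for agonist activity at Glucose-dependent insulinotropic receptor (Homo sapiens), read by HTRF and cAMP accumulation; on this read-out lower numbers stand for smaller maximal responses and higher numbers for larger maximal responses:
- compound 1, `CC(C)OC(=O)N1CCC(O[C@H]2CC[C@H](Oc3cnc(S(C)(=O)=O)cn3)CC2)CC1`: 110%
- compound 2, `CC1(OC(=O)N2CCC(O[C@H]3CC[C@H](Oc4cnc(S(C)(=O)=O)cn4)CC3)CC2)CC1`: 118%
- compound 3, `CS(=O)(=O)c1cnc(O[C@H]2CC[C@H](OC3CCN(C(=O)OC4CCOC4)CC3)CC2)cn1`: 105%

All three measured compounds share one core and differ only in the group on an oxygen next to a carbonyl group. The changes there moved the response little: a number 8 percentage points higher from compound 1 to compound 2 (within the scatter), a number 5 percentage points lower from compound 1 to compound 3 (within the scatter), and a number 13 percentage points lower from compound 2 to compound 3 (beyond the scatter). Compound 3 stands lowest of the three numbers, though its nearest neighbour, compound 1, lies within the scatter of it, and only compound 2 sits beyond the scatter above it.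

Compound 4, `CS(=O)(=O)c1cnc(O[C@H]2CC[C@H](OC3CCN(CC4(C(F)(F)F)CCC4)CC3)CC2)cn1`, is not yet measured. It differs from compound 3 as follows: (1-(trifluoromethyl)cyclobutyl)methyl in place of ((oxolan-3-yl)oxy)carbonyl on an amine nitrogen in a ring. Among the measured compounds shown here, none of the measured steps touches this kind of change: each of them kept the carbonyl and its oxygens and swapped only the group on the oxygen, whereas here the whole carbonyl-bearing group leaves and a ring of carbon only enters on the amine nitrogen. The measured steps therefore give no direct guide, beyond showing that the shared core supports a full maximal response throughout. The expectation for compound 4 in this assay is a response near those seen, estimated as a number 5 percentage points lower from compound 3 to compound 4 (within the scatter), with wider uncertainty than among the measured compounds. Compound 4 is expected to give 100%, between 70% and 125%.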

Compound 4, largest response reached (Emax), in percent of the reference or control that the assay uses: 96%
Compound 4: the middle estimate sits 4 percentage points above what was measured; measured number inside the range.
By their numbers in this assay, from the lowest: compounds 4, 3, 1 and 2 (each within the scatter of the next, the first and the last beyond it).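

In this assay, the amine nitrogen in the six-membered ring keeps a large response without any carbonyl group on it: placing (1-(trifluoromethyl)cyclobutyl)methyl there instead of ((oxolan-3-yl)oxy)carbonyl gives a number 9 percentage points lower from compound 3 to compound 4 (within the scatter). Measured against the two other carbonyl-bearing groups, the same kind of replacement gives a number 14 percentage points lower from compound 1 to compound 4 (beyond the scatter) and a number 22 percentage points lower from compound 2 to compound 4 (beyond the scatter), so the whole group can be exchanged for one of carbon and fluorine with only modest losses, and the earlier swaps on the oxygen could not have shown this. No measurement here accounts for these differences.

The change removes the carbonyl and its oxygens and brings in a four-membered ring and a trifluoromethyl group in one step, leaving open which of these parts the small shifts in response belong to. A plain cyclobutylmethyl group on the same nitrogen would isolate the part played by the trifluoromethyl group, and an acetyl group would show whether a carbonyl without the further oxygen behaves like the groups on compound 1, compound 2 and compound 3.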